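The source may hold more compounds than are shown below. What is called first, only, known or untested is meant among the compounds shown, and "the series" means these compounds.

Within the data shown here, in an ADME assay on MDCK cells (Canis lupus familiaris) for cytotoxicity, read by MTT assay, with a stated time of 24 h (on this read-out higher numbers stand for lower toxicity in this test and lower numbers for higher toxicity in this test), compound 3 (`Cc1ccc(S(=O)(=O)N(CCC#N)Cc2cccs2)cc1`) gives 127000 nM, the only actual number among the three compounds tested. Compound 1 (`N#CCCN(Cc1cccs1)S(=O)(=O)c1ccc(F)cc1`) reports only a limit, > 205000 nM. Compound 2 (`N#CCCN(Cc1cccs1)S(=O)(=O)c1ccc(Cl)cc1`) also reports only a limit, > 195000 nM. Compound 4 (`COc1ccc(S(=O)(=O)N(CCC#N)Cc2cccs2)cc1`) differs from compound 3 at one place: methoxy in place of methyl on an aromatic carbon. Among the measured compounds shown here, the steps that bear on this change are swaps on that same aromatic carbon: an at least 1.6-fold lower number from compound 1 to compound 3 (0.20 log units; that floor lies within the scatter) and an at least 1.5-fold lower number from compound 2 to compound 3 (0.18 log units; that floor lies within the scatter). The third is a step that the two limits leave unreadable from compound 1 to compound 2. None of these steps involves methoxy, and none is shown to exceed the scatter, so no step beyond the scatter is expected in this assay. The expected step is a 1.1-fold higher number from compound 3 to compound 4 (0.04 log units; within the scatter). For compound 4, the estimated value is 140000 nM, with an expected range of 70000 nM to 200000 nM.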

Compound 4, half-maximal cytotoxic concentration: > 198000 nM
Compound 4 gave a limit, no number; the forecaster's own chance of this, stated with the estimate: 35%; middle value at least 1.4-fold (0.15 log units) from the limit.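

In this assay, methoxy on the aromatic carbon para to a large group gives an at least 1.5-fold higher number from compound 3 to compound 4 (0.19 log units; that floor lies within the scatter). Among these compounds, compound 4 therefore joins the compounds that report a limit and not a number: the limit of > 198000 nM in this assay, at which 1 of the 4 values shown sits. The steps from compounds 1 and 2 to compound 4 cannot be read, as all three values are limits, which leaves methyl as the only group at this position with an actual number.

From the compounds shown here alone, how far the values of the limited compounds lie from that of compound 3 remains open. So does whether an amine or a carboxylic acid on this carbon would give a number.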